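The source may report more compounds than this note shows. Statements on the series, on what has been measured and on what is new or still open speak of the compounds shown alone.

Of the compounds shown here, three built on one shared core have been tested in an assay on CHO-K1 cells for agonist activity at Orexin receptor type 2 (Homo sapiens), read by a luciferase reporter; on this read-out lower numbers stand for an effect already at smaller amounts and higher numbers for an effect only at larger amounts of compound. Compound 1, `COc1ccccc1C(=O)NCCNc1cccc(NS(=O)(=O)c2cc(-c3ccccc3)ccc2OC)c1`, carries a plain phenyl ring on that core. In this assay compound 1 gives > 10000 nM, which is a limit of the assay rather than a number. Compound 2, `COc1ccccc1C(=O)NCCNc1cccc(NS(=O)(=O)c2cc(-c3cccc(C(=O)N4CCC4)c3)ccc2OC)c1`, adds an (azetidin-1-yl)carbonyl group to that ring, and in this assay compound 2 gives 235 nM. That change is an at least 42-fold lower number from compound 1 to compound 2 (1.62 log units; beyond the scatter). Compound 3, `COc1ccccc1C(=O)NCCNc1cccc(NS(=O)(=O)c2cc(-c3cccc(F)c3)ccc2OC)c1`, carries fluoro instead. In this assay compound 3 gives > 10000 nM, again a limit and not a number. Compound 3 thus stands at the limit of > 10000 nM in this assay, at which 2 of the 3 values shown sit, together with compound 1. The related steps are an at least 42-fold higher number from compound 2 to compound 3 (1.62 log units; beyond the scatter) and a step that the two limits leave unreadable from compound 1 to compound 3.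

Compound 4, `COc1ccccc1C(=O)NCCNc1cccc(NS(=O)(=O)c2cc(-c3cccnc3)ccc2OC)c1`, differs from compound 3 by pyridin-3-yl in place of 3-fluorophenyl on an aromatic carbon. The measured steps on this ring show one large gain, from the amide of compound 2, and no readable change from fluoro. A single hetero atom in the ring is a smaller alteration than the amide, so compound 4 is expected to remain near the limit, with an at least 1.2-fold lower number from compound 3 to compound 4 (0.09 log units; that floor lies within the scatter) as the estimated step. The expected value for compound 4 in this assay is 8000 nM, with a range from 2000 nM to 30000 nM.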

Compound 4, half-maximal effective concentration: 268 nM
For compound 4 the middle estimate is 30-fold (1.47 log units) above the measured one; the whole stated range lies above it.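

Changing the ring itself turns out to matter at this position: in this assay, pyridin-3-yl, with its single ring nitrogen and one hydrogen-bond acceptor, gives an at least 37-fold lower number from compound 3 to compound 4 (1.57 log units; beyond the scatter), and the same group in place of plain phenyl gives an at least 37-fold lower number from compound 1 to compound 4 (1.57 log units; beyond the scatter). For the compounds shown here, the (azetidin-1-yl)carbonyl group is therefore not the only change on this ring that gives a readable value, for the much smaller pyridin-3-yl group lands level with it, with a 1.1-fold higher number from compound 2 to compound 4 (0.06 log units; within the scatter). Compound 1 and compound 3, whose rings carry neither a ring nitrogen nor that amide, remain at a limit of the assay rather than a number: the limit of > 10000 nM in this assay, at which 2 of the 4 values shown sit.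

The compounds shown cannot tell whether the position of the ring nitrogen or the hydrogen-bond acceptor as such is what counts, a question that a pyridin-4-yl ring or a phenyl ring bearing a nitrile would address. From the compounds shown here alone, it also stays open whether the ring nitrogen and the (azetidin-1-yl)carbonyl group would add up if placed together on one pyridine ring.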